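The source may hold more compounds than are shown below. What is called first, only, known or untested is meant among the compounds shown, and "the series" means these compounds.

Measured compounds:
Compound 1 `CC(C)=CCC/C(C)=C/CC/C(C)=C/CC[C@@H]1[C@@]2(C)CC/C(=N\OCc3cn(-c4c(Cl)cc([N+](=O)[O-])cc4Cl)nn3)C(C)(C)[C@@H]2CC[C@@]1(C)O` — in a functional assay on HeLa cells (Homo sapiens) for cytotoxicity, read by MTT assay, with a stated time of 48 h (on this read-out lower numbers stand for stronger inhibition and higher numbers for weaker inhibition), compound 1 gives 23000 nM
Compound 2 `COc1cc(OC)c(-n2cc(CO/N=C3\CC[C@]4(C)[C@@H](CC/C=C(\C)CC/C=C(\C)CCC=C(C)C)[C@](C)(O)CC[C@H]4C3(C)C)nn2)c(OC)c1` — in this assay compound 2 gives 12800 nM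
Compound 3 `CC(C)=CCC/C(C)=C/CC/C(C)=C/CC[C@@H]1[C@@]2(C)C/C(=C\c3ccc(OCc4cn(-c5c(Cl)cc([N+](=O)[O-])cc5Cl)nn4)cc3)C(=O)C(C)(C)[C@@H]2CC[C@@]1(C)O` — in this assay compound 3 gives 36900 nM

Compounds 1 and 2 share one core and differ in a single place: 2,4,6-trimethoxyphenyl in place of 2,6-dichloro-4-nitrophenyl on an aromatic nitrogen. That change gave a 1.8-fold lower number from compound 1 to compound 2 (0.25 log units; within the scatter). Compound 3 carries a different core; how the two cores differ is not broken down here. Compound 2 gives a lower number than compound 3, a gap described as beyond the scatter, while compound 1 and compound 3 lie within the scatter of each other.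

Compound 4 `COc1cc(OC)c(-n2cc(COc3ccc(/C=C4\C[C@]5(C)[C@@H](CC/C=C(\C)CC/C=C(\C)CCC=C(C)C)[C@](C)(O)CC[C@H]5C(C)(C)C4=O)cc3)nn2)c(OC)c1` is not yet measured. It differs from compound 3 by 2,4,6-trimethoxyphenyl in place of 2,6-dichloro-4-nitrophenyl on an aromatic nitrogen, the same change as between compound 1 and compound 2, at the same place. Resting on the step seen from compound 1 to compound 2, compound 4 is expected to show a 1.8-fold lower number from compound 3 to compound 4 (0.24 log units; within the scatter), a step of much the same size as a 1.8-fold lower number from compound 1 to compound 2 (0.25 log units; within the scatter). Compound 4 is estimated at 21000 nM, between 9000 nM and 45000 nM.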

Compound 4, half-maximal inhibitory concentration: 17500 nM
Beside the measured number, compound 4's estimate is 1.2-fold (0.08 log units) above it; the range from low to high includes it.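

In this assay, 2,4,6-trimethoxyphenyl in place of 2,6-dichloro-4-nitrophenyl on the aromatic nitrogen gave a 2.1-fold lower number from compound 3 to compound 4 (0.32 log units; beyond the scatter), and the two steps for this change agree: the same change on two cores in this assay, a 1.8-fold lower number (0.25 log units; within the scatter) from compound 1 to compound 2 and a 2.1-fold lower number (0.32 log units; beyond the scatter) from compound 3 to compound 4, 1.2-fold (0.07 log units) apart, within the scatter of two such steps. For the compounds shown here, the change therefore carried over from one core to the other at much the same size and in the same direction, although only the step on the second core lies beyond the scatter. This rests on just two pairs and shows neither why the number moves nor that the step would hold on a third core.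

From the compounds shown here alone, it remains open whether a phenyl bearing an amine or a carboxylic acid on that aromatic nitrogen would follow the same step. Also open, going by these compounds, is whether either core would respond alike to such a group.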